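Hydroxy in Place of Nitro: Compound 3 to Compound 4

A few compounds are considered here, and "the series" means these few. Any claim that something is new, unique, unknown or untested is made for them only; others in the source may bear on it.

Three compounds have been measured in an assay on SK-N-MC cells for inhibition of Neuropeptide Y receptor type 1 (Homo sapiens); a lower number here means a stronger inhibitor, a higher number a weaker inhibitor:

Compound 1, `COC(=O)C1=C(C)N=C(C)/C(=C(/O)OC)C1c1cccc(N/C(=N/CCNC2CCN(c3ccccc3)CC2)NC#N)c1`, gives 10 nM.
Compound 2, `COC(=O)C1=C(C)N=C(C)/C(=C(/O)OC)C1c1cccc(N/C(=N/CCNC2CCN(c3ccccc3SC)CC2)NC#N)c1`, gives 3 nM.
Compound 3, `COC(=O)C1=C(C)N=C(C)/C(=C(/O)OC)C1c1cccc(NC(=O)NCCNC2CCN(c3ccccc3[N+](=O)[O-])CC2)c1`, gives 2 nM.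

Compound 3 stands at the lowest of the three numbers. Its gap to compound 2 lies within the scatter, so the two cannot be ordered; its gap to compound 1 lies beyond it. Compound 4, `COC(=O)C1=C(C)N=C(C)/C(=C(/O)OC)C1c1cccc(NC(=O)NCCNC2CCN(c3ccccc3O)CC2)c1`, has not yet been measured in this assay. It differs from compound 3 in one place: hydroxy in place of nitro on an aromatic carbon.

Among the compounds with values here, only one measured step touches the same aromatic ring: a 3.3-fold lower number from compound 1 to compound 2 (0.52 log units; beyond the scatter). That step concerns a different group entering where hydrogen stood, so it shows merely that this ring position tolerates a substituent and can shift the number by a modest amount. Within the data shown here, no measured pair compares nitro with hydroxy, and compound 3 carries a urea where compounds 1 and 2 carry a cyanoguanidine, so the step between them does not transfer directly.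

Compound 4 is therefore expected to stay close to compound 3, with a modest rise in the number as the more likely direction: a 2.0-fold higher number from compound 3 to compound 4 (0.30 log units; within the scatter). The estimate for compound 4 in this assay is 4 nM, with a range from 1.5 nM to 12 nM.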

Compound 4, half-maximal inhibitory concentration: 6 nM
Beside the measured number, compound 4's estimate is 1.5-fold (0.18 log units) below it, and the stated range covers the measured number.
By their numbers in this assay, from the lowest: compounds 3, 2, 4 and 1 (each within the scatter of the next, the first and the last beyond it).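

In this assay, within the data shown here, hydroxy in place of nitro on this aromatic carbon, ortho to a large group, gives a 3.0-fold higher number from compound 3 to compound 4 (0.48 log units; beyond the scatter) and is the first measured comparison of two substituents at this place, where the earlier step compared a substituent only with hydrogen. The step is modest but beyond the scatter, so the number at this place depends on which of these two groups is present, and compound 4 still gives 6 nM with hydroxy, which has 1 heavy atom and 1 hydrogen-bond donor, in place of nitro, which has 3 heavy atoms and 0 hydrogen-bond donors. No measurement offered here accounts for the rise, so the step describes the number alone.

The compounds shown leave open how an amine, a methoxy group or a carboxylic acid at this place would compare with nitro and hydroxy. They also leave open whether the step from nitro to hydroxy would keep its direction and size on a cyanoguanidine in place of the urea, and how methylsulfanyl would read on the urea.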